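The source may hold more compounds than are shown below. What is called first, only, known or untested is meant among the compounds shown, and "the series" means these compounds.

In a functional assay on MCF7 cells (Homo sapiens) for inhibition, read by CCK-8 assay, with a stated time of 48 h (a lower number here means a stronger inhibitor, a higher number a weaker inhibitor), compound 2 `COc1cc(-c2ccnc3cc(-c4ccc5cc[nH]c5c4)nn23)cc(OC)c1OC` gives 23 nM. Among the three compounds measured, compound 2 stands within the scatter of compound 1 `COc1cc(-c2ccnc3cc(-c4cn(CO)c5ccccc45)nn23)cc(OC)c1OC`, which gives 19 nM, and well apart from compound 3 `COc1cc(-c2ccnc3cc(-c4cn(C(=O)OC(C)(C)C)c5ccccc45)nn23)cc(OC)c1OC`, which gives 268 nM; the gap to compound 3 lies beyond the scatter. The one measured step among these compounds, a 14-fold higher number from compound 1 to compound 3 (1.15 log units; beyond the scatter), concerns a change on an aromatic nitrogen, not on the aromatic carbon changed here, so it bears only indirectly on what follows. Compound 4 `COc1cc(-c2ccnc3cc(-c4ccc5cnn(C)c5c4)nn23)cc(OC)c1OC` differs from compound 2 in one place: 1-methyl-1H-indazol-6-yl in place of 1H-indol-6-yl on an aromatic carbon. For the measured compounds named here, no measured step describes this exchange, and the data offer no pair that swaps a 1H-indol-6-yl for a 1-methyl-1H-indazol-6-yl. What the numbers do show is that compounds 1 and 2, which carry different ring substituents at this part of the shared core, sit within the scatter of each other, which suggests the core tolerates some variation there. On that basis, the step from compound 2 to compound 4 is expected to be small, a 1.5-fold higher number from compound 2 to compound 4 (0.18 log units; within the scatter), with no strong direction. Compound 4 is therefore estimated at 35 nM in this assay, in the range 10 nM to 120 nM.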

Compound 4, half-maximal inhibitory concentration: 279 nM
Beside the measured number, compound 4's estimate is 8.0-fold (0.90 log units) below it; measured number above the stated range.
By their numbers in this assay, from the lowest: compounds 1 and 2 (each within the scatter of the next); then compounds 3 and 4 (each within the scatter of the next).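

For the compounds shown here, the group on this aromatic carbon of the five-membered aromatic ring matters more than the earlier compounds indicated: in this assay, replacing 1H-indol-6-yl with 1-methyl-1H-indazol-6-yl gives a 12-fold higher number from compound 2 to compound 4 (1.08 log units; beyond the scatter), a large step beyond the scatter. Compounds 1 and 2 carry different groups here yet stand within the scatter of each other, so this result shows that the position does not accept every fused aromatic group equally. The exchange alters several features at once, since the entering group has a second ring nitrogen and a methyl and has no hydrogen-bond donor, whereas the leaving group has one, and no measurement shown explains why the number rises.

Going by these compounds alone, the single step cannot say whether the second ring nitrogen, the methyl or the loss of the donor accounts for the change, a question that 1H-indazol-6-yl and 1-methyl-1H-indol-6-yl would help to separate. On these data alone, it also remains open how the shared core would respond to a primary amine or a carboxylic acid on the six-membered ring of the 1H-indol-6-yl group.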